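A few compounds are considered here, and "the series" means these few. Any claim that something is new, unique, unknown or untested is made for them only; others in the source may bear on it.

Working notes on the series. In a functional assay on MIA PaCa-2 cells (Homo sapiens) for inhibition, read by MTT assay, with a stated time of 7 days (on this read-out lower numbers stand for stronger inhibition and higher numbers for weaker inhibition), compound 1 `CCOC(=O)[C@@H]1CCC[C@@H](S(=O)(=O)c2ccc(S(=O)(=O)N(CC)CC)cc2)C1` gives 16400 nM. Compound 2 `CCOC(=O)[C@@H]1C[C@@H](O)CN(S(=O)(=O)c2ccc(S(=O)(=O)N(CC)CC)cc2)C1` gives 7900 nM in this assay. Compound 3 `CCN(CC)C(=O)c1ccc(S(=O)(=O)N2CCC[C@@H](C(=O)N3CCN(c4nc(C(C)C)no4)CC3)C2)cc1` gives 100 nM in this assay, the lowest of the three numbers; its gap to compound 2 and its wider gap to compound 1 both lie beyond the scatter. Compound 4 `CCC(CC)S(=O)(=O)c1ccc(S(=O)(=O)N2CCC[C@@H](C(=O)N3CCN(c4nc(C(C)C)no4)CC3)C2)cc1` has not yet been measured. It differs from compound 3 in one place: (pentan-3-yl)sulfonyl in place of diethylcarbamoyl on an aromatic carbon. Going by the values given here, no measured pair isolates this change, since compounds 1 and 2 differ from compound 3 elsewhere as well. The step from compound 3 to compound 4 is expected to be small, toward a somewhat higher number or none beyond the scatter: a 1.6-fold higher number from compound 3 to compound 4 (0.20 log units; within the scatter). Compound 4 is expected to give 160 nM, within 50 nM to 600 nM.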

Compound 4, half-maximal inhibitory concentration: 50 nM
The estimate for compound 4 lay 3.2-fold (0.51 log units) above the measured number, and the stated range covers the measured number.
By their numbers in this assay, from the lowest: compounds 4 and 3 (each within the scatter of the next); then compound 2; then compound 1.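

Going by these compounds alone, the only pair that isolates the group on this aromatic carbon, para to a large group, gives a 2.0-fold lower number from compound 3 to compound 4 (0.30 log units; within the scatter) in this assay, with (pentan-3-yl)sulfonyl in place of diethylcarbamoyl. At this position, then, the sulfonyl group and the carbamoyl group cannot be told apart in this read-out, although the entering group brings sulfur in place of nitrogen and one more hydrogen-bond acceptor. Nothing available accounts for this result. Open, on these data alone, is whether a carboxylic acid or an amine at this position would stay within the scatter of these two compounds.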